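Compound 3 to compound 4: methyl for hydrogen on nitrogen

The source may hold more compounds than are shown below. What is called first, only, known or untested is meant among the compounds shown, and "the series" means these compounds.

Compound 3 `CN(C)CCCOc1ccc(CNc2nc3ccc(Oc4ccc(C#N)cc4)cc3s2)cc1` stands lowest of the three numbers: in an assay on cells for inhibition of Voltage-dependent T-type calcium channel subunit alpha-1H (Homo sapiens), read by FLIPR and calcium flux, with stated times of 600 s and 300 s (a lower number here means a stronger inhibitor, a higher number a weaker inhibitor), compound 3 gives 41000 nM. Compound 2 `CN(Cc1ccc(OCCCNC(=N)N)cc1)c1nc2ccc(Oc3ccc(C#N)cc3)cc2s1` gives 153000 nM and compound 1 `CN(Cc1ccc(OCCCN)cc1)c1nc2ccc(Oc3ccc(C#N)cc3)cc2s1` gives 328000 nM. Going by the values given here, the one measured step, a 2.1-fold lower number from compound 1 to compound 2 (0.33 log units; beyond the scatter), concerns the group on the amine nitrogen and not the nitrogen on the aromatic ring. Compound 4 `CN(C)CCCOc1ccc(CN(C)c2nc3ccc(Oc4ccc(C#N)cc4)cc3s2)cc1` differs from compound 3 by methyl in place of hydrogen on a nitrogen on an aromatic ring. Among the compounds with values here, no measured step bears directly on this change; compounds 1 and 2 already carry the methyl but differ from compound 3 elsewhere as well, so their values cannot be split between the two changes. The expectation is therefore a step of no clear direction, a 1.2-fold higher number from compound 3 to compound 4 (0.09 log units; within the scatter), within or near the scatter. Compound 4 is expected at 50000 nM, range 15000 nM to 160000 nM.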

Compound 4, half-maximal inhibitory concentration: 64000 nM
The estimate for compound 4 lay 1.3-fold (0.11 log units) below the measured number; measured number inside the range.
By their numbers in this assay, from the lowest: compounds 3 and 4 (each within the scatter of the next); then compound 2; then compound 1.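

Methyl in place of hydrogen on the nitrogen on an aromatic ring gives the first direct reading of this change, and the step lies within the scatter (a 1.6-fold higher number from compound 3 to compound 4 (0.19 log units; within the scatter)). With that methyl present, dimethylamino in place of amino on the saturated chain carbon gives a step beyond the scatter (a 5.1-fold lower number from compound 1 to compound 4 (0.71 log units; beyond the scatter)), as does the change of group at that carbon (a 2.4-fold lower number from compound 2 to compound 4 (0.38 log units; beyond the scatter)). No evidence accounts for these steps. The compounds shown leave open how ethyl on the same nitrogen would read, and how a longer chain carrying dimethylamino would compare.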